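The source may hold more compounds than are shown below. What is called first, only, known or untested is meant among the compounds shown, and "the series" means these compounds.

Measured so far, all read in an ADME assay on THP-1 cells (Homo sapiens) for cytotoxicity, read by MTT assay, with a stated time of 72 h; on this read-out lower numbers stand for stronger inhibition and higher numbers for weaker inhibition:
compound 3 `Cc1ccc(/C=C/C(=O)c2c(O)c3ccccc3[nH]c2=O)cc1`, a limit only: > 50000 nM
compound 2 `COc1ccc(/C=C/C(=O)c2c(O)c3ccccc3[nH]c2=O)cc1`, a limit only: > 50000 nM
compound 1 `O=C(/C=C/C=C/c1ccccc1)c1c(O)c2ccccc2[nH]c1=O`, a limit only: > 50000 nM

Compound 3 therefore stands nowhere distinct on the numbers: every value in this assay sits at the limit of > 50000 nM in this assay, at which 3 of the 3 values shown sit. Compound 4 `COc1cccc(/C=C/C(=O)c2c(O)c3ccccc3[nH]c2=O)c1` differs from compound 3 in one place: 3-methoxyphenyl in place of 4-methylphenyl on a double-bonded chain carbon bound to a double-bonded chain carbon. Within the data shown here, the steps that bear on this change are a step that the two limits leave unreadable from compound 1 to compound 3 and a step that the two limits leave unreadable from compound 2 to compound 3; a step that the two limits leave unreadable from compound 1 to compound 2 is equally unreadable, so no size in either direction can be drawn from the series. The expectation is that compound 4 also returns a limit, with an expected step that the limit leaves unreadable from compound 3 to compound 4. Compound 4 is estimated at 80000 nM, in the range 30000 nM to 300000 nM.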

Compound 4, half-maximal inhibitory concentration: 38500 nM
Beside the measured number, compound 4's estimate is 2.1-fold (0.32 log units) above it; the range from low to high includes it.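

In this assay, among these compounds, the 3-methoxyphenyl group on this double-bonded chain carbon gives the first reading that is a number and not a limit. Set against 4-methylphenyl (an at least 1.2-fold lower number from compound 3 to compound 4 (0.11 log units; that floor lies within the scatter)), 4-methoxyphenyl (an at least 1.2-fold lower number from compound 2 to compound 4 (0.11 log units; that floor lies within the scatter)) and 2-phenylethenyl (an at least 1.2-fold lower number from compound 1 to compound 4 (0.11 log units; that floor lies within the scatter)), this change yields floors only, so its true size stays unknown, and the steps among the earlier compounds cannot be read. The other compounds remain limits: the limit of > 50000 nM in this assay, at which 3 of the 4 values shown sit.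

Open, as far as these compounds go, is whether the reading depends on the methoxy group itself or on where it sits on the ring. Also open, from the compounds shown here alone, is how an amine or a carboxylic acid would read at this place.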